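Replacing the pyridine with a difluorophenyl on the piperazine

This account rests on a few compounds, and the source may have more. Where it says the series, first, only, none or still open, it means among the compounds named here.

Three compounds share one core and differ only in the aromatic group on the ring nitrogen. Compound 1 `Nc1scc(CN2CCN(c3cc(Cl)cc(Cl)c3)CC2)c1C(=O)c1ccc(Cl)cc1` gives -22% in a functional assay on CHO cells with adenosine receptor A1 (Homo sapiens) as the target, read by cAMP accumulation and immunoassay, with a stated time of 6 min, tested at 0.1 uM (on this read-out lower numbers stand for a stronger effect and higher numbers for a weaker effect at the one concentration tested), compound 2 `Nc1scc(CN2CCN(c3cccc(C(F)(F)F)c3)CC2)c1C(=O)c1ccc(Cl)cc1` gives -30%, and compound 3 `Nc1scc(CN2CCN(c3ccncc3)CC2)c1C(=O)c1ccc(Cl)cc1` gives 1.4%, the highest of the three and thus the weakest effect among them. Compound 4 `Nc1scc(CN2CCN(c3cc(F)cc(F)c3)CC2)c1C(=O)c1ccc(Cl)cc1` carries 3,5-difluorophenyl in place of pyridin-4-yl on an amine nitrogen in a ring. Among the measured compounds shown here, the steps that bear on this change ran the other way: a number 23.4 percentage points higher from compound 1 to compound 3 (beyond the scatter) and a number 31.4 percentage points higher from compound 2 to compound 3 (beyond the scatter), both beyond the scatter. Since the group entering compound 4 resembles that of compound 1, the estimate is a drop of about a number 16.4 percentage points lower from compound 3 to compound 4 (beyond the scatter) from compound 3 to compound 4. Compound 4 is therefore expected to give about -15%, within a range from -40% to 10%.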

Compound 4, a percentage reported as activity, at one concentration (the size of the read-out at that concentration, not a potency): -5%
Estimate against measurement, compound 4: 10 percentage points below; the range from low to high includes it.
By their numbers in this assay, from the lowest: compounds 2 and 1 (each within the scatter of the next); then compounds 4 and 3 (each within the scatter of the next).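

In this assay, 3,5-difluorophenyl and pyridin-4-yl on the ring nitrogen do not separate: a number 6.4 percentage points lower from compound 3 to compound 4 (within the scatter). An aromatic ring of carbon only is therefore not enough to reach the lower numbers, as the other two carbon-only groups show: a number 17 percentage points higher from compound 1 to compound 4 (beyond the scatter), and a number 25 percentage points higher from compound 2 to compound 4 (beyond the scatter). Nothing measured here explains why these groups differ. On these data alone, it remains open whether a methoxy group or an amine on the phenyl ring would give a number close to that of compound 1 or close to that of compound 4.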